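Pyridine in Place of Methyl on the Amide Carbonyl

The source may hold more compounds than are shown below. What is called first, only, known or untested is meant among the compounds shown, and "the series" means these compounds.

Compound 1, `COc1ccc(-c2cnc(NC(=O)c3cccc(O)c3)n2C)cc1`: > 100000 nM
Compound 2, `COc1ccc(-c2cnc(NC(C)=O)n2C)cc1`: > 100000 nM

In a toxicity assay on THP-1 cells (Homo sapiens) for inhibition (a higher number here means that more compound is tolerated, a lower number that less compound is tolerated), compound 1 gives > 100000 nM, which is a limit of the assay and not a number. Compound 2 in this assay gives > 100000 nM, likewise a limit. The step that the two limits leave unreadable from compound 1 to compound 2 is unreadable. Compound 2 stands at the limit, as the limit of > 100000 nM in this assay, at which 2 of the 2 values shown sit, shows. Compound 3, `COc1ccc(-c2cnc(NC(=O)c3ccccn3)n2C)cc1`, differs from compound 2 by pyridin-2-yl in place of methyl on a carbonyl carbon. Among the compounds with values here, no measured step bears on this change, so no step beyond the scatter is expected in this assay. Compound 3 is estimated at 100000 nM, between 40000 nM and 250000 nM, an expected step of a number no higher from compound 2 to compound 3 (the limit leaves the size open).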

Compound 3, half-maximal cytotoxic concentration: > 100000 nM
Compound 3 was reported as a limit; the forecaster's own chance of this, stated with the estimate: 80%; the middle value sits exactly at the limit.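

Compound 3 is also reported only as a limit, so the steps among compound 1, compound 2 and compound 3 cannot be read: the limit of > 100000 nM in this assay, at which 3 of the 3 values shown sit.

The compounds shown leave open how much of each is tolerated in this assay, and whether the group on the carbonyl carbon matters there at all.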